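Opening the urea terminus: from compound 1 to compound 3

The compounds below may be only part of what the source reports. "The series", "measured", "known", "first", "only" and "open" are said of these compounds alone.

Compound 1 `COc1ncc(-c2ccc3nc(NC(=O)N4CCCC4)nn3c2)cc1NS(=O)(=O)c1ccc(F)cc1` carries a pyrrolidin-1-yl group on the carbonyl carbon of its urea. Among the compounds with values here, in a functional assay on MCF7 cells (Homo sapiens) for cytotoxicity, read by MTT assay, with a stated time of 72 h (on this read-out lower numbers stand for stronger inhibition and higher numbers for weaker inhibition), compound 1 gives 1660 nM, the highest of the two numbers measured so far. Its nearest neighbour is compound 2 `COc1ncc(-c2ccc3nc(NC(=O)NCCN4CCCC4)nn3c2)cc1NS(=O)(=O)c1ccc(F)cc1`, which in this assay gives 380 nM. Within the data shown here, the single measured step, a 4.4-fold lower number from compound 1 to compound 2 (0.64 log units; beyond the scatter), is the only one that bears on the present question, and it is of modest size.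

Compound 3 `COc1ncc(-c2ccc3nc(NC(=O)NCCN4CCN(C)CC4)nn3c2)cc1NS(=O)(=O)c1ccc(F)cc1` is the next member to be measured. (2-(4-methylpiperazin-1-yl)ethyl)amino in place of pyrrolidin-1-yl on a carbonyl carbon The change is of the same kind as the measured step: the closed pyrrolidin-1-yl on the carbonyl carbon is again replaced by an ethyl-linked amino group ending in a saturated ring, here (2-(4-methylpiperazin-1-yl)ethyl)amino. Among the measured compounds shown here, no measured step tells how the two ring ends compare with each other. For the measured compounds named here, on the one measured step, a downward move of similar size is expected, a 4.2-fold lower number from compound 1 to compound 3 (0.62 log units; beyond the scatter). For compound 3 in this assay the estimate is 400 nM, with a range from 150 nM to 1100 nM.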

Compound 3, half-maximal inhibitory concentration: 500 nM
Compound 3: middle estimate off by 1.3-fold (0.10 log units), on the low side, and the stated range covers the measured number.
By their numbers in this assay, from the lowest: compounds 2 and 3 (each within the scatter of the next); then compound 1.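

In this assay, a second ethyl-linked amino group on the carbonyl carbon also lowers the number (a 3.3-fold lower number from compound 1 to compound 3 (0.52 log units; beyond the scatter)), so the change seen with compound 2 is not tied to a single ring end: (2-(pyrrolidin-1-yl)ethyl)amino and (2-(4-methylpiperazin-1-yl)ethyl)amino both stand lower than the closed pyrrolidin-1-yl. The ring ends can now be compared directly, and 4-methylpiperazin-1-yl in place of pyrrolidin-1-yl on the saturated chain carbon leaves the two compounds within the scatter of each other (a 1.3-fold higher number from compound 2 to compound 3 (0.12 log units; within the scatter)). Nothing on hand gives a reason for either step.

In both steps from compound 1, the ethyl chain and its terminal ring enter together, so the compounds shown do not separate what each contributes. An ethyl chain ending in a morpholine ring or a plain dimethylamino group, or a longer propyl chain carrying the same pyrrolidine ring, would bear on that question.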